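The source may hold more compounds than are shown below. What is called first, only, known or untested is meant among the compounds shown, and "the series" means these compounds.

Of the compounds shown here, three sharing one core have been read in a physicochemical assay for pharmacokinetics; on this read-out higher numbers stand for a longer-lived compound and lower numbers for a shorter-lived compound: compound 1 `O=C(NCc1cccc(Br)c1)N1C(=O)c2ccccc2S1(=O)=O` with 3-bromophenyl, compound 2 `Cc1ccccc1CNC(=O)N1C(=O)c2ccccc2S1(=O)=O` with 2-methylphenyl and compound 3 `O=C(NCC1CCCCC1)N1C(=O)c2ccccc2S1(=O)=O` with cyclohexyl, each on a saturated chain carbon bound to an amide-type nitrogen. Compound 1 gives > 166 h, which is a limit and not a number. Compound 2 gives > 166 h, again a limit. Compound 3 gives > 166 h, likewise a limit, so its true half-life is not known. Among the compounds with values here, the whole series so far comes to the limit of > 166 h in this assay, at which 3 of the 3 values shown sit.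

Compound 4 `COc1ccccc1CNC(=O)N1C(=O)c2ccccc2S1(=O)=O` is now to be read, and it carries 2-methoxyphenyl in place of the cyclohexyl of compound 3 at that same place: 2-methoxyphenyl in place of cyclohexyl on a saturated chain carbon bound to an amide-type nitrogen. The measured steps that bear on this change swap groups at the same position. They are a step that the two limits leave unreadable from compound 1 to compound 2, a step that the two limits leave unreadable from compound 1 to compound 3 and a step that the two limits leave unreadable from compound 2 to compound 3. None of them has a readable size, and none shows a direction. With all three compounds at one limit, the only expectation the data support is no step beyond the scatter. The expected change is a step that the limit leaves unreadable from compound 3 to compound 4. Compound 4 is estimated at 250 h, with an expected range of 150 h to 500 h, and the read-out may well be only a limit again.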

Compound 4, half-life: > 166 h
Compound 4: only a limit was reported (the forecaster's own chance of this, stated with the estimate: 85%); the middle value lies beyond the limit too.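

In this assay compound 4 gives > 166 h and that is a limit, not a number. Its steps from compound 1, compound 2 and compound 3 cannot be read, and the series stands as before: the limit of > 166 h in this assay, at which 4 of the 4 values shown sit. The compounds shown leave open how long each one actually lasts and whether any change at this place alters the half-life.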